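Hydroxy for azido on the sugar ring: cytotoxicity notes

This account rests on a few compounds, and the source may have more. Where it says the series, first, only, none or still open, it means among the compounds named here.

Three nucleoside analogues have been run in an ADME assay on HL-60 cells (Homo sapiens) for cytotoxicity, read by MTT assay, with a stated time of 3 days; on this read-out lower numbers stand for higher toxicity in this test and higher numbers for lower toxicity in this test. Compound 1 `O=c1nc(NO)c(F)cn1[C@@H]1C[C@@H](O)[C@H](CO)O1` gives 1370000 nM; compound 2 `Cc1cn([C@@H]2CC[C@H](CO)O2)c(=O)nc1N` gives 950000 nM; compound 3 `[N-]=[N+]=N[C@@H]1C[C@@H](n2ccc(NO)nc2=O)O[C@H]1CO` gives 2000000 nM. Compound 3 and compound 1 lie within the scatter of each other, while compound 2 sits beyond it at a lower number. Compound 4 `O=c1nc(NO)ccn1[C@@H]1C[C@@H](O)[C@H](CO)O1` has not yet been run in this assay. It differs from compound 3 by hydroxy in place of azido on a saturated ring carbon. For the measured compounds named here, no step between measured compounds covers this change. The step of a 1.3-fold lower number from compound 3 to compound 4 (0.12 log units; within the scatter) is expected to be none beyond the scatter, because compound 1 with the same hydroxy group gives 1370000 nM. Compound 4 is therefore expected at 1500000 nM, with a range of 600000 nM to 4000000 nM.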

Compound 4, half-maximal cytotoxic concentration: 460000 nM
Beside the measured number, compound 4's estimate is 3.3-fold (0.51 log units) above it, outside the stated range (below it).
By their numbers in this assay, from the lowest: compound 4; then compounds 2, 1 and 3 (each within the scatter of the next, the first and the last beyond it).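

Hydroxy in place of azido on the saturated ring carbon gives a 4.3-fold lower number from compound 3 to compound 4 (0.64 log units; beyond the scatter) in this assay, so this position is not indifferent to the change when the aromatic carbon bears hydrogen. With hydroxy held constant, hydrogen in place of fluoro on an aromatic carbon gives a 3.0-fold lower number from compound 1 to compound 4 (0.47 log units; beyond the scatter), so the number for a hydroxy compound also depends on that aromatic site. Nothing available gives a reason for either step.

Going by these compounds, whether an amine or a methoxy group on the same saturated ring carbon tracks hydroxy or azido stays open. So does whether chloro on the aromatic carbon tracks fluoro or hydrogen.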